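A few compounds are considered here, and "the series" means these few. Any claim that something is new, unique, unknown or untested is made for them only; others in the source may bear on it.

In an ADME assay on microsomes from liver (Rattus norvegicus) for metabolic stability (on this read-out lower numbers stand for slow clearance and higher numbers for fast clearance), compound 1 (`Cc1ccc(NC(=O)c2cc(Oc3ccc(S(C)(=O)=O)cc3)cc(OC(C)C)c2)nc1`) gives 97 mL/min/kg and compound 2 (`CC(C)Oc1cc(Oc2ccc(S(C)(=O)=O)cc2)cc(-c2cncc(=O)[nH]2)c1`) gives 61 mL/min/kg while compound 3 (`Cc1cc(=O)[nH]c(-c2cc(Oc3ccc(S(C)(=O)=O)cc3)cc(OC(C)C)c2)n1`) gives 96 mL/min/kg on the same scale. Compound 3 sits together with the other two: all three numbers lie within the usual scatter of one another, so they cannot be ranked.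

The next compound is compound 4 (`COc1cnc(-c2cc(Oc3ccc(S(C)(=O)=O)cc3)cc(OC(C)C)c2)[nH]c1=O`). Its difference from compound 3 is a group of 9 heavy atoms (5 carbon, 2 nitrogen, 2 oxygen; one six-membered aromatic ring with 2 hetero atoms) in place of a group of 8 heavy atoms (5 carbon, 2 nitrogen, 1 oxygen; one six-membered aromatic ring with 2 hetero atoms), on an aromatic carbon and the place is meta to a large group and meta to an isopropoxy group.

Three measured steps changed the group at this same place. They are a 1.0-fold lower number from compound 1 to compound 3 (0.00 log units; within the scatter) and a 1.6-fold lower number from compound 1 to compound 2 (0.20 log units; within the scatter) and a 1.6-fold higher number from compound 2 to compound 3 (0.20 log units; within the scatter) and each one stays within the scatter. Within the data shown here, no measured compound carries the entering group, so the data offer no direct precedent. The closest guide is the step between the two compounds with a six-membered aromatic ring with 2 hetero atoms, a 1.6-fold higher number from compound 2 to compound 3 (0.20 log units; within the scatter) and it gives no sign of a real shift. In this assay the expected change is a 1.1-fold lower number from compound 3 to compound 4 (0.05 log units; within the scatter) and it stays within the scatter with no firm direction. For compound 4 the estimated value is 85 mL/min/kg with an expected range of 50 mL/min/kg to 135 mL/min/kg in repeated measurements.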

Compound 4, clearance: < 25.4 mL/min/kg
Compound 4: a limit, no number; the forecaster's own chance of this, stated with the estimate: 5%; middle value at least 3.3-fold (0.52 log units) away from the limit.
By their numbers in this assay, from the lowest: compounds 2, 3 and 1 (each within the scatter of the next). At a limit, below all of these: compound 4.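

Among the groups shown on this aromatic carbon of a six-membered aromatic ring of carbon only, the earlier swaps all stayed within the scatter in this assay, so the clearance seemed not to respond to changes at this place, but the group in compound 4 breaks that picture (an at least 3.7-fold lower number from compound 3 to compound 4 (0.57 log units; beyond the scatter)). The value for compound 4 is a limit of the assay and not a number: the limit of < 25.4 mL/min/kg in this assay, at which 1 of the 4 values shown sits. The same separation appears against the other two compounds (an at least 2.4-fold lower number from compound 2 to compound 4 (0.38 log units; beyond the scatter)) and (an at least 3.8-fold lower number from compound 1 to compound 4 (0.58 log units; beyond the scatter)), so a change at this place can take the clearance of this series clear of the range the other three compounds share.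

The compounds shown leave open how far the clearance of compound 4 really falls, since each of these steps gives only a minimum size. They also leave open which part of the entering group carries the change: the same ring with an ethoxy group or a chlorine atom in place of the methoxy group would begin to separate the substituent from the ring itself.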